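The source may report more compounds than this note shows. Statements on the series, on what has been measured and on what is new or still open speak of the compounds shown alone.

Two measured compounds and one unmeasured compound share the same core, a long chain carrying a chlorophenoxy end and a thiourea joined to a carbonyl. Compound 1 `O=C(NC(=S)n1ccc2c(OCCCCCOc3ccc(Cl)cc3)cccc21)c1ccccc1` and compound 2 `N#Cc1ccc(C(=O)NC(=S)N2CCc3c(OCCCCCOc4ccc(Cl)cc4)cccc32)cc1` have been tested in an ADME assay on Huh-7 cells (Homo sapiens) for cytotoxicity; on this read-out higher numbers stand for lower toxicity in this test and lower numbers for higher toxicity in this test. In this assay compound 1 gives 29500 nM. For compound 2 this assay reports > 50000 nM, which is a limit of the assay and not a number. On the numbers shown, compound 2 therefore stands at the limit of > 50000 nM in this assay, at which 1 of the 2 values shown sits.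

Compound 3 `O=C(NC(=S)N1CCc2c(OCCCCCOc3ccc(Cl)cc3)cccc21)c1ccco1` has not yet been measured. It differs from compound 2 in one place: furan-2-yl in place of 4-cyanophenyl on a carbonyl carbon. Going by the values given here, no step between two measured compounds is available, so the size of this change cannot be read off anything measured. With compound 2 sitting at a limit and compound 1 also showing low toxicity, the expectation is that compound 3 stays in the same weakly toxic region, with a step from compound 2 to compound 3 of an at least 1.1-fold lower number from compound 2 to compound 3 (0.04 log units; that floor lies within the scatter) expected, no larger than the usual scatter. Compound 3 is estimated at 45000 nM, within a range from 20000 nM to 100000 nM.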

Compound 3, half-maximal cytotoxic concentration: 4620 nM
Beside the measured number, compound 3's estimate is 9.7-fold (0.99 log units) above it, outside the stated range (below it).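

In this assay, putting furan-2-yl in place of 4-cyanophenyl on the carbonyl carbon gives an at least 10-fold lower number from compound 2 to compound 3 (1.03 log units; beyond the scatter), the first measured sign that the group at this one place can by itself shift the read-out towards higher toxicity in this test. The size of that step is a floor and not an exact figure, as its starting point is a limit of the assay and not a number: the limit of > 50000 nM in this assay, at which 1 of the 3 values shown sits. The change also swaps several features at once, since a six-membered aromatic ring of carbon only gives way to a five-membered aromatic ring with a hetero atom and the nitrile is lost, so this single step cannot say which of these differences matters.

Still open, on these data alone, is where a plain phenyl group or a thiophen-2-yl group on the same carbonyl carbon, with the rest of compound 2 unchanged, would fall, which would help separate the loss of the nitrile from the change of ring. As far as these compounds go, it is also open whether furan-2-yl has a similar effect on the core of compound 1, and whether a change to the long chain would shift the read-out as much as this one did.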